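Methyl for hydrogen repeated on a second core

A few compounds are considered here, and "the series" means these few. Any claim that something is new, unique, unknown or untested is made for them only; others in the source may bear on it.

Compound 1 `CCOC(=O)c1c(-c2c(Cl)c3ccccc3oc2=O)nn(-c2ccccc2)c1C(=O)OCC` gives 34000 nM in a functional assay on A549 cells (Homo sapiens) for cytotoxicity, read by MTT assay, with a stated time of 48 h; on this read-out lower numbers stand for stronger inhibition and higher numbers for weaker inhibition. Compound 2 `CCOC(=O)c1c(-c2c(Cl)c3cc(C)ccc3oc2=O)nn(-c2ccccc2)c1C(=O)OCC` carries methyl in place of hydrogen on an aromatic carbon and gives 108000 nM, so that a 3.2-fold higher number from compound 1 to compound 2 (0.50 log units; beyond the scatter). Compound 3 `CCOC(=O)c1c(-c2cc3ccc(OCC=C(C)C)cc3oc2=O)nn(-c2ccccc2)c1C(=O)OCC` gives 136000 nM; the difference between its core and the core of compound 1 is not broken down here, and its value and that of compound 2 lie within the scatter of each other. Compound 4 `CCOC(=O)c1c(-c2cc3ccc(OCC=C(C)C)cc3oc2=O)nn(-c2cccc(C)c2)c1C(=O)OCC` carries methyl in place of hydrogen on an aromatic carbon. This is the same kind of change as from compound 1 to compound 2, not the same: there the place was part of a fused or bridged system of two rings, meta to a fused ring and para to a fused ring, whereas here it is meta to a large group on a ring of carbon only. Because a 3.2-fold higher number from compound 1 to compound 2 (0.50 log units; beyond the scatter), a step in the same direction is expected, a 1.8-fold higher number from compound 3 to compound 4 (0.26 log units; within the scatter), but the changed place leaves it uncertain. Compound 4 is estimated at 250000 nM, between 100000 nM and 600000 nM.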

Compound 4, half-maximal inhibitory concentration: 178000 nM
Compound 4: the middle estimate sits 1.4-fold (0.15 log units) above what was measured; the measured number falls inside the stated range.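

Carried to a second core in this assay, methyl in place of hydrogen on an aromatic carbon gives a 1.3-fold higher number from compound 3 to compound 4 (0.12 log units; within the scatter), so on this core the step is not resolved from the scatter. Going by these compounds alone, the gap between this step and the earlier one is also within the scatter, so the data give no sign that the core alters the size of the step: the same change on two cores in this assay, a 3.2-fold higher number (0.50 log units; beyond the scatter) from compound 1 to compound 2 and a 1.3-fold higher number (0.12 log units; within the scatter) from compound 3 to compound 4, 2.4-fold (0.39 log units) apart, within the scatter of two such steps This does not show that the change transfers reliably, since there are only two pairs, the methyl stands at a different place in each, and one step alone lies beyond the scatter.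

Still open, on these data alone, is whether a group other than methyl at this place on the phenyl ring, such as an amine or a carboxylic acid, would move the number beyond the scatter.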